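Swapping a brominated phenol for an indole at the hydrazone

The source may report more compounds than this note shows. Statements on the series, on what has been measured and on what is new or still open speak of the compounds shown alone.

Compound 3 `CN(C)CCn1cnnc1-c1cc(Oc2ccc(NC(=O)N/N=C/c3ccc(O)c(Br)c3)cc2F)ccn1` gives 430 nM in a functional assay on NCI-H460 cells (Homo sapiens) for cytotoxicity, read by MTT assay, with a stated time of 72 h (a lower number here means a stronger inhibitor, a higher number a weaker inhibitor), the lowest of the three numbers as they stand, though its gap to compound 1 lies within the scatter. Compound 1 `CN(C)CCn1cnnc1-c1cc(Oc2ccc(NC(=O)N/N=C/c3ccc(F)cc3Cl)cc2F)ccn1` gives 720 nM, and compound 2 `CN(C)CCn1cnnc1-c1cc(Oc2ccc(NC(=O)N/N=C/c3ccc(O)cc3)cc2F)ccn1` gives 1780 nM. The step of a 1.7-fold lower number from compound 1 to compound 3 (0.22 log units; within the scatter) is within the scatter, whereas a 2.5-fold higher number from compound 1 to compound 2 (0.39 log units; beyond the scatter) and a 4.1-fold lower number from compound 2 to compound 3 (0.62 log units; beyond the scatter) are modest but real. Compound 4 `CN(C)CCn1cnnc1-c1cc(Oc2ccc(NC(=O)N/N=C/c3c[nH]c4ccccc34)cc2F)ccn1` has not yet been measured in this assay. It differs from compound 3 in one place: 1H-indol-3-yl in place of 3-bromo-4-hydroxyphenyl on a carbon with a double bond to nitrogen. Within the data shown here, no measured step places a 1H-indol-3-yl group on the carbon with a double bond to nitrogen, so the nearest guidance comes from the exchanges already made there, a 1.7-fold lower number from compound 1 to compound 3 (0.22 log units; within the scatter) and a 2.5-fold higher number from compound 1 to compound 2 (0.39 log units; beyond the scatter), which moved the number by modest amounts in either direction. A modest step is therefore expected for compound 4 as well, with its direction left open by the data. A somewhat higher number is taken as the middle estimate because compound 3 already stands lowest at 430 nM. As an estimate, a 1.6-fold higher number from compound 3 to compound 4 (0.21 log units; within the scatter). Compound 4 is expected to give 700 nM in this assay, within a range of 250 nM to 2000 nM.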

Compound 4, half-maximal inhibitory concentration: 1630 nM
Estimate against measurement, compound 4: 2.3-fold (0.37 log units) below; the measured number falls inside the stated range.
By their numbers in this assay, from the lowest: compounds 3 and 1 (each within the scatter of the next); then compounds 4 and 2 (each within the scatter of the next).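

In this assay, 1H-indol-3-yl on the carbon with a double bond to nitrogen offers no advantage over the halogen-bearing groups, since a 3.8-fold higher number from compound 3 to compound 4 (0.58 log units; beyond the scatter) and a 2.3-fold higher number from compound 1 to compound 4 (0.35 log units; beyond the scatter) both lie beyond the scatter. The second ring of this group also does not separate it from the plain phenol: a 1.1-fold lower number from compound 2 to compound 4 (0.04 log units; within the scatter) lies within the scatter, so among these four compounds the two with a halogen on the ring, compound 1 and compound 3, give the lower numbers, and no compound goes against this split. No measured evidence explains why the numbers fall this way at this position.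

From the compounds shown here alone, it remains open whether a bromo group on the 1H-indol-3-yl ring would bring a step like a 4.1-fold lower number from compound 2 to compound 3 (0.62 log units; beyond the scatter), which would show whether the effect of the bromine carries over from the phenol to a two-ring group. Also open, going by these compounds, is how a phenyl ring carrying an amine or a carboxylic acid would behave at this same place, and whether either would reach the level of compound 3.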